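A few compounds are considered here, and "the series" means these few. Any claim that something is new, unique, unknown or untested is made for them only; others in the source may bear on it.

Measured so far in a functional assay on HEL cells (Homo sapiens), read by microscopy; a higher number here means that more compound is tolerated, a lower number that less compound is tolerated:
compound 1 `CCCCCCCCc1cc2cn(COCCO)c(O)nc-2n1` gives 80000 nM.
compound 2 `CCCCCCCCC#Cc1cc2cn(COCCO)c(=O)nc2o1` gives a limit, >= 20000 nM.
compound 3 `CCCCC#Cc1cc2cn(COCCO)c(=O)nc2o1` gives a limit, > 100000 nM.

Within the data shown here, compound 1 carries the only number in the set; the other two values are limits of this assay. For compound 2 the limit is the limit of >= 20000 nM in this assay, at which 1 of the 3 values shown sits. For compound 3 the limit is the limit of > 100000 nM in this assay, at which 1 of the 3 values shown sits. Between these two stands one change, (hydrogen in place of butyl on a saturated chain carbon, four bonds along the chain from a triple-bonded carbon), and the step it makes is a step that the two limits leave unreadable from compound 2 to compound 3. How the core of compound 1 differs from the core of compound 2 is not broken down here.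

Compound 4 `CCCCc1cc2cn(COCCO)c(O)nc-2n1` is not yet measured. It differs from compound 1 by hydrogen in place of butyl on a saturated chain carbon, four bonds along the chain from an aromatic carbon. This is the same kind of change as that from compound 2 to compound 3, though not the same: there the saturated chain carbon sits four bonds along the chain from a triple-bonded carbon, here four bonds along the chain from an aromatic carbon. Since the step from compound 2 to compound 3 has no readable size, the expectation rests on compound 1 at 80000 nM alone, with the change assumed to leave the tolerated concentration roughly where it stands or to raise it. The expected step is a 1.3-fold higher number from compound 1 to compound 4 (0.10 log units; within the scatter). Compound 4 is estimated at 100000 nM, between 40000 nM and 300000 nM, with a fair chance that only a limit is returned.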

Compound 4, minimum cytotoxic concentration: > 400000 nM
Compound 4 was reported as a limit; the forecaster's own chance of this, stated with the estimate: 50%; middle value at least 4.0-fold (0.60 log units) from the limit.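

On the core of compound 1, hydrogen in place of butyl gives, in this assay, an at least 5.0-fold higher number from compound 1 to compound 4 (0.69 log units; beyond the scatter), so the shorter chain is tolerated at a higher concentration on this core. On the core of compound 2, the same kind of change, there four bonds along the chain from a triple-bonded carbon, gives a step that cannot be read, as compound 2 and compound 3 both stand as limits. The change is therefore sized on one core only: the compounds show no conflict between the two cores, but they do not show that the step carries from one to the other.

On these data alone, the full size of the step stays open, as the value of compound 4 is a limit and the step gives only a lower bound. Also open, as far as these compounds go, is where a hexyl chain would fall on the core of compound 1, and how an amine or a carboxylic acid at that place would read in this assay.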